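The source may hold more compounds than are shown below. What is called first, only, known or untested is meant among the compounds shown, and "the series" means these compounds.

Compound 1 `CCCCCCCNc1ccc(C(=O)C2CC2c2ccc(Cl)cc2)cc1`: 398 ug/mL
Compound 2 `CCCCCCCCCCCCCCCCNc1ccc(C(=O)C2CC2c2ccc(Cl)cc2)cc1`: 410 ug/mL

In an ADME assay on Vero cells (Chlorocebus sabaeus) for cytotoxicity, with a stated time of 72 h (a higher number here means that more compound is tolerated, a lower number that less compound is tolerated), compound 1 gives 398 ug/mL and compound 2 gives 410 ug/mL, the two numbers lying within the scatter of each other. Compound 3 `O=C(c1ccc(N2CCCCC2)cc1)C1CC1c1ccc(Cl)cc1` has not yet been measured. It differs from compound 1 by piperidin-1-yl in place of heptylamino on an aromatic carbon on an aromatic carbon of the shared core. Within the data shown here, the one measured step, which altered the chain on that same nitrogen, was a 1.0-fold higher number from compound 1 to compound 2 (0.01 log units; within the scatter); it does not test a ring closing, so it bears on the change only loosely. Nothing therefore points to a step beyond the scatter, and a step of a 1.1-fold lower number from compound 1 to compound 3 (0.04 log units; within the scatter) is expected. Compound 3 is estimated at 360 ug/mL, with a range from 150 ug/mL to 750 ug/mL.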

Compound 3, half-maximal cytotoxic concentration: 284 ug/mL
Estimate against measurement, compound 3: 1.3-fold (0.10 log units) above, within the range that was stated.
By their numbers in this assay, from the lowest: compounds 3, 1 and 2 (each within the scatter of the next).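

Among these compounds, putting piperidin-1-yl in place of heptylamino on this aromatic carbon gives, in this assay, a 1.4-fold lower number from compound 1 to compound 3 (0.15 log units; within the scatter), so a six-membered non-aromatic ring with no hydrogen-bond donor is the first change at this position that goes beyond altering the chain. The change brings in the ring and removes the donor together, and the compounds cannot separate the two. No measurement here accounts for the step. On these data alone, it remains open whether morpholin-4-yl, piperazin-1-yl or a simple amino group on this carbon would also stay within the scatter of compound 1.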